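Swapping a benzimidazole for an aminothiazole on the thioether arm

The source may report more compounds than this note shows. Statements on the series, on what has been measured and on what is new or still open speak of the compounds shown alone.

Three compounds share one core and differ only in the group carried on a saturated chain carbon bound to a sulfur. Compound 1 `N#Cc1c(N)nc(SCC(N)=O)c(C#N)c1-c1ccc(OCC2CC2)cc1` gives 8% in an assay on CHO cells for displacement of a labelled ligand from adenosine receptor A3 (Homo sapiens), read by scintillation counting, with a stated time of 120 min, tested at 1 uM; on this read-out higher numbers stand for more inhibition at the one concentration tested (going by the name of the read-out) and lower numbers for less inhibition. Compound 2 `N#Cc1c(N)nc(SCC(=O)NCO)c(C#N)c1-c1ccc(OCC2CC2)cc1` gives 8%, and compound 3 `N#Cc1c(N)nc(SCc2nc3ccccc3[nH]2)c(C#N)c1-c1ccc(OCC2CC2)cc1` gives 1%. All three numbers are small, and compound 3 sits at the low end of the three only within the usual scatter: the steps of a number 7 percentage points lower from compound 1 to compound 3 (within the scatter) and a number 7 percentage points lower from compound 2 to compound 3 (within the scatter) are both too small to count as real differences, as is no change at the digits printed from compound 1 to compound 2 (within the scatter).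

Compound 4 `N#Cc1c(N)nc(SCc2csc(N)n2)c(C#N)c1-c1ccc(OCC2CC2)cc1` is the next variation at the same position: 2-amino-1,3-thiazol-4-yl in place of 1H-benzimidazol-2-yl on a saturated chain carbon bound to a sulfur. The two steps that bear on this change, from compound 1 and from compound 2 to compound 3, exchanged groups at exactly this place and moved the read-out by no more than the scatter. Since every group tried here has left inhibition low, compound 4 is expected to behave likewise, with a step of a number 4 percentage points higher from compound 3 to compound 4 (within the scatter) that stays inside the scatter. The estimate for compound 4 is therefore 5%, with a likely range from -5% to 15%.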

Compound 4, a percentage reported as inhibition, at one concentration (the size of the read-out at that concentration, not a potency): 1%
The estimate for compound 4 lay 4 percentage points above the measured number, within the range that was stated.
By their numbers in this assay, from the lowest: compounds 3, 4, 1 and 2 (each within the scatter of the next).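

In this assay, giving up the six-membered aromatic ring of carbon only and bringing in a sulfur-containing 2-amino-1,3-thiazol-4-yl leaves no change at the digits printed from compound 3 to compound 4 (within the scatter), so this second ring-bearing group on the saturated chain carbon bound to a sulfur reads like the first. Set against the open-chain groups, the same thiazole gives a number 7 percentage points lower from compound 2 to compound 4 (within the scatter) and a number 7 percentage points lower from compound 1 to compound 4 (within the scatter), so for these four compounds neither amide-type nor aromatic ring groups at this place separate from one another. No other data bearing on this result are available, and so the flat read-out remains unexplained.

On these data alone, whether a carboxylic acid, a plain amine or a longer chain between the sulfur and the ring would give a higher number remains open. So does whether any change elsewhere on the shared core would move this read-out.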